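Propyl in place of ethyl on the ring nitrogen

The source may report more compounds than this note shows. Statements on the series, on what has been measured and on what is new or still open speak of the compounds shown alone.

Measured compounds:
compound 1 `CCCn1c(-c2ccccc2)nc2c(NC3CCC3)ncnc21` — 15 nM
compound 2 `CCCn1c(-c2ccccc2)nc2c(NC3CCCC3)ncnc21` — 10 nM
compound 3 `CCn1c(-c2ccccc2)nc2c(N)ncnc21` — 31 nM

All three were read in an assay on CHO cells for displacement of a labelled ligand from adenosine receptor A1 (Homo sapiens), read by scintillation counting, with a stated time of 3 h; on this read-out lower numbers stand for stronger inhibition and higher numbers for weaker inhibition. Compound 3 gives the highest number of the three: in this assay compound 3 gives 31 nM, while compound 1 gives 15 nM and compound 2 gives 10 nM.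

Compound 4 `CCCn1c(-c2ccccc2)nc2c(N)ncnc21` is not yet measured. It differs from compound 3 by methyl in place of hydrogen on a saturated chain carbon, two bonds along the chain from an aromatic nitrogen; the amine on the shared core is untouched.

Among the measured compounds shown here, the only measured step, a 1.5-fold lower number from compound 1 to compound 2 (0.18 log units; within the scatter), concerns the cycloalkyl on the amine nitrogen, not the chain on the ring nitrogen, so it does not bear directly on this change. For the measured compounds named here, no measured pair shows the chain alone being lengthened. Compounds 1 and 2, which carry the propyl chain, give lower numbers than compound 3, but they also carry a different amine, so that gap cannot be credited to the chain. The expected step in this assay from compound 3 to compound 4 is therefore a 1.2-fold lower number from compound 3 to compound 4 (0.09 log units; within the scatter), which is not expected to go beyond the scatter. Compound 4 is estimated at 25 nM, with a range of 10 nM to 60 nM.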

Compound 4, inhibition constant: 101 nM
Beside the measured number, compound 4's estimate is 4.0-fold (0.61 log units) below it, outside the stated range (above it).
By their numbers in this assay, from the lowest: compounds 2 and 1 (each within the scatter of the next); then compound 3; then compound 4.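

In this assay, among the compounds shown here, the one change of ethyl to propyl, methyl in place of hydrogen on a saturated chain carbon, two bonds along the chain from an aromatic nitrogen, gives a 3.3-fold higher number from compound 3 to compound 4 (0.51 log units; beyond the scatter), so this position does respond to the change, and in the direction of weaker inhibition. With the propyl chain held fixed, hydrogen on the amine nitrogen gives a 10-fold higher number from compound 2 to compound 4 (1.00 log units; beyond the scatter) and a 6.7-fold higher number from compound 1 to compound 4 (0.83 log units; beyond the scatter), so the lower numbers of compounds 1 and 2 go with their cycloalkyl groups and not with the chain. Each of these steps lies beyond the scatter. The compounds shown leave open whether a butyl chain would raise the number further, and whether the ethyl to propyl step carries over when the amine bears cyclobutyl or cyclopentyl. Nothing available accounts for the size of these steps.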